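This account rests on a few compounds, and the source may have more. Where it says the series, first, only, none or still open, it means among the compounds named here.

Measured compounds:

Compound 1 `COc1cc(-n2cnc3ccc(-c4cccc(F)c4)cc32)cc(OC)c1OC`: 2350 nM
Compound 2 `COc1cc(-n2cnc3ccc(-c4cccc([N+](=O)[O-])c4)cc32)cc(OC)c1OC`: 4560 nM

Both compounds share the same core and differ only in the group on its aromatic carbon; both were tested in a functional assay on MCF7 cells (Homo sapiens) for antiproliferative activity, read by MTT assay, with a stated time of 72 h; a lower number here means a stronger inhibitor, a higher number a weaker inhibitor. Compound 2 carries the numerically larger of the two numbers, yet the step of a 1.9-fold higher number from compound 1 to compound 2 (0.29 log units; within the scatter) lies within the scatter, so nothing separates the two compounds.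

Compound 3 `CCOc1ccc(-c2ccc3ncn(-c4cc(OC)c(OC)c(OC)c4)c3c2)cc1` is the next compound on this core. The change is 4-ethoxyphenyl in place of 3-nitrophenyl on an aromatic carbon. Within the data shown here, no measured step covers a 4-ethoxyphenyl group or this swap; the only step at hand is the one from compound 1 to compound 2, and it stays within the scatter. On that thin basis no shift beyond the scatter is expected, and the step from compound 2 to compound 3 is estimated as a 1.4-fold lower number from compound 2 to compound 3 (0.15 log units; within the scatter). For compound 3 the expected value in this assay is 3200 nM, with a range from 1000 nM to 10000 nM.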

Compound 3, half-maximal inhibitory concentration: 1710 nM
Compound 3: middle estimate off by 1.9-fold (0.27 log units), on the high side; low and high end bracket the measured number.
By their numbers in this assay, from the lowest: compounds 3, 1 and 2 (each within the scatter of the next, the first and the last beyond it).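

In this assay, among these compounds, there is a 2.7-fold lower number from compound 2 to compound 3 (0.43 log units; beyond the scatter) when 4-ethoxyphenyl replaces 3-nitrophenyl, the first step at this position that lies beyond the scatter, though a modest one. Against 3-fluorophenyl, the same group gives only a 1.4-fold lower number from compound 1 to compound 3 (0.14 log units; within the scatter) and stays within the scatter, so compound 1 and compound 3 cannot be told apart, and the difference appears only against compound 2. Nothing available here explains this step.

The swap changes both the substituent and its place on the phenyl ring, so the compounds shown cannot separate these two changes; a 3-ethoxyphenyl or 4-nitrophenyl group would be needed to do so. They also leave open how an amine, a carboxylic acid or a longer chain in place of the ethoxy group would behave.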